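Replacing 3-methylthiophen-2-yl with 4-methylphenyl in compound 1

The compounds below may be only part of what the source reports. "The series", "measured", "known", "first", "only" and "open" are said of these compounds alone.

Among the measured compounds shown here, in a functional assay on SGC-7901 cells (Homo sapiens) for cytotoxicity, read by MTT assay, with a stated time of 38 h (on this read-out higher numbers stand for weaker inhibition and lower numbers for stronger inhibition), compound 1 `COc1cc(OC)c2c(=O)c(OCC(=O)N/N=C/c3sccc3C)c(-c3cc(OC)c(OC)c(OC)c3)oc2c1` gives 10300 nM, the lower of the two numbers measured so far. The other measured molecule, compound 2 `COc1cc(OC)c2c(=O)c(OCCCCN3CCCC3)c(-c3cc(OC)c(OC)c(OC)c3)oc2c1`, gives 26800 nM. The next molecule, compound 3 `COc1cc(OC)c2c(=O)c(OCC(=O)N/N=C/c3ccc(C)cc3)c(-c3cc(OC)c(OC)c(OC)c3)oc2c1`, keeps the shared core of compound 1 and differs in a single group: 4-methylphenyl in place of 3-methylthiophen-2-yl on a carbon with a double bond to nitrogen. In words, 4-methylphenyl stands in place of 3-methylthiophen-2-yl on a carbon with a double bond to nitrogen, so one aromatic ring carrying a methyl group is exchanged for another.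

For the measured compounds named here, only one measured step offers any guidance. It is modest and lies beyond the scatter: a 2.6-fold higher number from compound 1 to compound 2 (0.42 log units; beyond the scatter). That step removes the whole group on a saturated chain carbon bound to an oxygen on an aromatic ring, so it is a much broader change and bears only loosely on this one. Going by the values given here, no measured pair isolates a swap of this kind, which leaves the direction open. The expected change is therefore none beyond the scatter in this assay, and the estimated step is a 1.2-fold higher number from compound 1 to compound 3 (0.07 log units; within the scatter). The estimate for compound 3 is 12000 nM, with an expected range from 5000 nM to 28000 nM.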

Compound 3, half-maximal inhibitory concentration: 10100 nM
The estimate for compound 3 lay 1.2-fold (0.07 log units) above the measured number; measured number inside the range.
By their numbers in this assay, from the lowest: compounds 3 and 1 (each within the scatter of the next); then compound 2.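

In this assay, putting 4-methylphenyl in place of 3-methylthiophen-2-yl on the carbon with a double bond to nitrogen gives a 1.0-fold lower number from compound 1 to compound 3 (0.01 log units; within the scatter) and so stays within the scatter: at this place, a six-membered aromatic ring of carbon only and a five-membered aromatic ring containing sulfur, each carrying a methyl group, cannot be told apart. The step of a 2.7-fold lower number from compound 2 to compound 3 (0.42 log units; beyond the scatter) lies beyond the scatter, as does a 2.6-fold higher number from compound 1 to compound 2 (0.42 log units; beyond the scatter), so the separation from compound 2, with its five-membered non-aromatic ring containing nitrogen, holds with either aromatic ring in the group. No outside evidence is available to explain why compound 1 and compound 3 give such closely matching numbers.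

The compounds shown leave open whether the methyl group itself matters, as both rings at this place carry one and plain phenyl is not among them. They also leave open whether a ring with a different substituent, such as a chlorine or a methoxy group, a pyridine ring or a saturated cyclohexyl ring would move the number in either direction.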